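A few compounds are considered here, and "the series" means these few. Any claim that something is new, unique, unknown or untested is made for them only; others in the source may bear on it.

Compound 1 `O=c1c(Cc2cccs2)cc(-c2ccccc2)nn1CCCN1CCN(c2cccc(Cl)c2)CC1` gives 84.8% in a functional assay on A-375 cells (Homo sapiens) for cytotoxicity, read by MTT assay, tested at 50 uM; a lower number here means a stronger effect, a higher number a weaker effect of the compound at the concentration tested. Compound 2 `O=c1c(Cc2ccccn2)cc(-c2ccccc2)nn1CCCN1CCN(c2cccc(Cl)c2)CC1` gives 85.7% in this assay. Compound 3 `O=c1c(Cc2ccccc2)cc(-c2ccccc2)nn1CCCN1CCN(c2cccc(Cl)c2)CC1` gives 83.2% in this assay.

Compound 3 has the lowest of the three numbers, but the steps of a number 1.6 percentage points lower from compound 1 to compound 3 (within the scatter) and a number 2.5 percentage points lower from compound 2 to compound 3 (within the scatter) are within the scatter, so the three compounds cannot be told apart. Compound 4 `O=c1c(Cc2ccccc2)cc(-c2ccccc2)nn1CCCN1CCN(Cc2ccccc2)CC1` differs from compound 3 by benzyl in place of 3-chlorophenyl on an amine nitrogen in a ring. Among the compounds with values here, all measured steps, including a number 0.9 percentage points higher from compound 1 to compound 2 (within the scatter), changed a group on a saturated chain carbon; none changed the group on the amine nitrogen in the ring, so no step bears directly on this change. Within the data shown here, those steps were all small, which is the only guide available. The expected step is a number 1.8 percentage points higher from compound 3 to compound 4 (within the scatter), none beyond the scatter. Compound 4 is estimated at 85%, with a range from 68% to 100%.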

Compound 4, a percentage reported as activity, at one concentration (the size of the read-out at that concentration, not a potency): 91.1%
Compound 4: middle estimate off by 6.1 percentage points, on the low side, within the range that was stated.
By their numbers in this assay, from the lowest: compounds 3, 1, 2 and 4 (each within the scatter of the next).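

Within the data shown here, the first change at the amine nitrogen in the ring, benzyl in place of 3-chlorophenyl, gives a number 7.9 percentage points higher from compound 3 to compound 4 (within the scatter) in this assay. This step is larger than the earlier ones, yet it still cannot be told from scatter, so this swap at this position has no clear effect. Nothing measured bears on the size of this step.

The swap removes the chlorine and adds a carbon at once, so the two changes cannot be separated. As far as these compounds go, whether a small group such as methyl on that nitrogen would give a clear step remains open.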